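Nitro on the phenyl of compound 3: working notes

The source may report more compounds than this note shows. Statements on the series, on what has been measured and on what is new or still open speak of the compounds shown alone.

Values in a functional assay on A549 cells (Homo sapiens) for inhibition, read by MTT assay, with a stated time of 72 h; a lower number here means a stronger inhibitor, a higher number a weaker inhibitor:
- compound 1 `Nc1ccccc1NC(=O)c1ccc(CNCc2nc(-c3ccc(Cl)cc3)no2)cc1`: 13500 nM
- compound 2 `Nc1ccccc1NC(=O)c1ccc(CNCc2nc(-c3cccs3)no2)cc1`: > 100000 nM (a limit)
- compound 3 `O=C(NO)c1ccc(CNCc2nc(-c3ccccc3)no2)cc1`: > 100000 nM (a limit)

Compound 3 gives > 100000 nM, which is a limit and not a number. Among the compounds with values here, it stands at the limit of > 100000 nM in this assay, at which 2 of the 3 values shown sit, so only one compound in the set has a true number so far.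

The next compound is compound 4 `O=C(NO)c1ccc(CNCc2nc(-c3ccc([N+](=O)[O-])cc3)no2)cc1`, with nitro in place of hydrogen on an aromatic carbon, para to a large group: nitro in place of hydrogen on an aromatic carbon. The phenyl of compound 3 thus becomes 4-nitrophenyl.

Within the data shown here, the only measured step at an aromatic group is an at least 7.4-fold higher number from compound 1 to compound 2 (0.86 log units; beyond the scatter), with thiophen-2-yl in place of 4-chlorophenyl. It bears on the change only loosely, since it concerns other groups on a different parent. It does show a substituted phenyl on the better side of that pair, and compound 1 at 13500 nM shows that a number can be reached in this assay. A lower number is therefore expected, modest in size if it appears at all, and the expected change is an at least 1.4-fold lower number from compound 3 to compound 4 (0.15 log units; that floor lies within the scatter). Compound 4 is estimated at 70000 nM, with an expected range of 15000 nM to 150000 nM, and another limit is quite likely.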

Compound 4, half-maximal inhibitory concentration: > 100000 nM
Compound 4: a limit, no number; the forecaster's own chance of this, stated with the estimate: 60%; at least 1.4-fold (0.15 log units) between middle value and limit.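

In this assay compound 4 gives > 100000 nM, which is a limit and not a number. Within the data shown here, compound 3 also stands at a limit, so no step from compound 3 to compound 4 can be read: the limit of > 100000 nM in this assay, at which 3 of the 4 values shown sit.

The compounds shown leave open whether nitro in place of hydrogen on an aromatic carbon changes the number at all.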